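From benzyl to 3-methoxyphenyl on an aromatic nitrogen

This account rests on a few compounds, and the source may have more. Where it says the series, first, only, none or still open, it means among the compounds named here.

In a functional assay on MDA-MB-231 cells (Homo sapiens) for antiproliferative activity, read by MTT assay, with a stated time of 72 h (a higher number here means a weaker inhibitor, a lower number a stronger inhibitor), compound 1 (`CCCCCn1ccnc1-c1cc(OC)c(OC)c(OC)c1`) gives 34200 nM. Compound 2 (`COc1cc(-c2nccn2Cc2ccccc2)cc(OC)c1OC`) gives > 100000 nM, which is a limit and not a number. It therefore stands at the limit of > 100000 nM in this assay, at which 1 of the 2 values shown sits.

Compound 3 (`COc1cccc(-n2ccnc2-c2cc(OC)c(OC)c(OC)c2)c1`) carries 3-methoxyphenyl in place of benzyl on an aromatic nitrogen. For the measured compounds named here, the only measured step at this nitrogen is an at least 2.9-fold higher number from compound 1 to compound 2 (0.46 log units; beyond the scatter), beyond the scatter, with phenyl in place of butyl on a saturated chain carbon. Going by the values given here, no measured step covers an aryl group bound directly to the nitrogen, so the guidance is weak. Compound 1 at 34200 nM shows that a measurable value is possible in this series, so a modest move to a lower number in this assay is expected. The expected change is an at least 3.3-fold lower number from compound 2 to compound 3 (0.52 log units; beyond the scatter). For compound 3 the estimated value is 30000 nM, with an expected range of 6000 nM to 100000 nM.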

Compound 3, half-maximal inhibitory concentration: 18300 nM
The estimate for compound 3 lay 1.6-fold (0.21 log units) above the measured number, within the range that was stated.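

An aryl group bound directly to the aromatic nitrogen gives a measurable value in this assay, whereas benzyl at the same place does not, and 3-methoxyphenyl in place of benzyl brings an at least 5.4-fold lower number from compound 2 to compound 3 (0.73 log units; beyond the scatter). From the compounds shown here alone, compound 2 gives only a limit and not a number, so the true size of this step stays unknown: the limit of > 100000 nM in this assay, at which 1 of the 3 values shown sits. Against the chain, 3-methoxyphenyl in place of pentyl brings a 1.9-fold lower number from compound 1 to compound 3 (0.27 log units; within the scatter), so in these data an open-chain alkyl group and this directly bound aryl group cannot be told apart at this nitrogen.

A plain phenyl on this nitrogen would separate the contribution of the methoxy group from that of the directly bound ring. Open too, going by these compounds, is whether a 3-aminophenyl or a longer chain ending in a carboxylic acid would move the value beyond the scatter from compound 3.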